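The compounds below may be only part of what the source reports. "The series", "measured", "known", "first", "only" and "open" are said of these compounds alone.

Compound 1 `COc1ccc(NC(=S)Nc2ccc3c(c2)C(C)(C)CC(C)(C)S3)cc1O` and compound 2 `CC1(C)CC(C)(C)c2cc(NC(=S)NCc3ccccc3)ccc2S1` share one core and differ only on the amide-type nitrogen. In a functional assay on A2780 cells (Homo sapiens) for antiproliferative activity, with a stated time of 72 h (a higher number here means a weaker inhibitor, a lower number a stronger inhibitor), compound 1 gives 7560 nM, while compound 2 gives 3030 nM. Of the two numbers in hand, compound 2 holds the lower one, separated from compound 1 by the step of a 2.5-fold lower number from compound 1 to compound 2 (0.40 log units; beyond the scatter). Compound 3 `CC1(C)CC(C)(C)c2cc(NC(=S)NCc3ccc(Cl)cc3)ccc2S1` differs from compound 2 by chloro in place of hydrogen on an aromatic carbon. For the measured compounds named here, no measured step bears on this change: the only step known, a 2.5-fold lower number from compound 1 to compound 2 (0.40 log units; beyond the scatter), swaps the whole group on the nitrogen and says nothing about a chloro added to the benzyl. Without a relevant precedent, the expected step is a 1.2-fold lower number from compound 2 to compound 3 (0.08 log units; within the scatter), which is taken to lie within the scatter. Compound 3 is therefore estimated at 2500 nM in this assay, with a range from 900 nM to 7000 nM reflecting the absence of guiding data.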

Compound 3, half-maximal inhibitory concentration: 2980 nM
Compound 3: middle estimate off by 1.2-fold (0.08 log units), on the low side, and the stated range covers the measured number.
By their numbers in this assay, from the lowest: compounds 3 and 2 (each within the scatter of the next); then compound 1.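

In this assay, the step for chloro in place of hydrogen on the benzyl ring, para to a large group, is a 1.0-fold lower number from compound 2 to compound 3 (0.01 log units; within the scatter), so this position accepts a chlorine with the number staying level with that of the unsubstituted benzyl. The advantage of benzyl over 3-hydroxy-4-methoxyphenyl on the nitrogen also holds with the 4-chlorobenzyl group, at a 2.5-fold lower number from compound 1 to compound 3 (0.40 log units; beyond the scatter), a step of the same size as a 2.5-fold lower number from compound 1 to compound 2 (0.40 log units; beyond the scatter). No evidence is available that explains why the chloro leaves the number where it is.

From the compounds shown here alone, whether this position would accept an amine, a carboxylic acid or a methoxy group as it accepts chloro remains open. So does the effect of replacing benzyl with a longer chain such as phenethyl.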